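From methoxy to 4-methylpiperidin-1-yl: compound 3 to compound 4

This account rests on a few compounds, and the source may have more. Where it says the series, first, only, none or still open, it means among the compounds named here.

Measured compounds:
compound 1, `COc1cccc(Nc2nccc(-c3ccc(C)o3)n2)c1` — 1500 nM
compound 2, `COc1cccc(Nc2nccc(-c3cc(C)oc3C)n2)c1` — 5800 nM
compound 3, `COc1cccc(Nc2nccc(-c3cccs3)n2)c1` — 900 nM

In a functional assay for inhibition, with Homo sapiens as the target (a lower number here means a stronger inhibitor, a higher number a weaker inhibitor), compound 3 gives 900 nM, the lowest of the three numbers. Compound 1 stands nearest, and the step of a 1.7-fold lower number from compound 1 to compound 3 (0.22 log units; within the scatter) lies within the scatter, so the two cannot be ordered. Compound 2 stands furthest, the step of a 6.4-fold lower number from compound 2 to compound 3 (0.81 log units; beyond the scatter) being beyond the scatter, as is a 3.9-fold higher number from compound 1 to compound 2 (0.59 log units; beyond the scatter).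

Compound 4, `CC1CCN(c2cccc(Nc3nccc(-c4cccs4)n3)c2)CC1`, differs from compound 3 in a single place: 4-methylpiperidin-1-yl in place of methoxy on an aromatic carbon. None of the three measured steps bears on this change; all of them swap the five-membered ring on the shared core and leave the methoxy group untouched. Within the data shown here, there is therefore no measured precedent for what a 4-methylpiperidin-1-yl group in this position does in this assay. With nothing to point either way, the expected step of no change at the digits printed from compound 3 to compound 4 (within the scatter) is none beyond the scatter, but the uncertainty is wide. Compound 4 is estimated at 900 nM in this assay, within a range from 200 nM to 4500 nM.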

Compound 4, half-maximal inhibitory concentration: 3500 nM
Compound 4: middle estimate off by 3.9-fold (0.59 log units), on the low side, within the range that was stated.
By their numbers in this assay, from the lowest: compounds 3 and 1 (each within the scatter of the next); then compounds 4 and 2 (each within the scatter of the next).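

Moving away from the five-membered ring for the first time, the change on this aromatic carbon, meta to a large group, shows that this position also affects the result in this assay: 4-methylpiperidin-1-yl in place of methoxy gives a 3.9-fold higher number from compound 3 to compound 4 (0.59 log units; beyond the scatter). The larger ring does not abolish inhibition, since compound 4 still gives 3500 nM. No measurement at hand accounts for the rise in the number.

As far as these compounds go, it remains open whether the step follows from the ring, its 4-methyl group or the nitrogen attached to the aromatic carbon, which an unsubstituted piperidin-1-yl, a morpholin-4-yl or a dimethylamino group in the same place could help to separate. From the compounds shown here alone, it is also open whether the same change would give a similar step with the 5-methylfuran-2-yl of compound 1 or the 2,5-dimethylfuran-3-yl of compound 2.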